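Trading a Sulfamoyl for an Ethoxy in a Sulfonamide Series

The source may hold more compounds than are shown below. What is called first, only, known or untested is meant among the compounds shown, and "the series" means these compounds.

Of the compounds shown here, three have been tested in an assay on isolated protein for inhibition of alkaline phosphatase, tissue-nonspecific isozyme (Bos taurus), read by chemiluminescence and spectrophotometry; a higher number here means a weaker inhibitor, a lower number a stronger inhibitor. Compound 1 `NS(=O)(=O)c1ccc(CNC(=O)c2ccc(F)cc2)cc1` gives 299 nM, compound 3 `NS(=O)(=O)c1cccc(NS(=O)(=O)c2ccc(F)cc2)c1` gives 60 nM, and compound 2 `Cc1ccc(S(=O)(=O)Nc2ccc(S(N)(=O)=O)cc2)cc1` gives 91900 nM, the highest number of the three and therefore the weakest inhibitor among them. All three carry a sulfamoyl group on a benzene ring. Compound 4 `CCOc1ccc(NS(=O)(=O)c2ccc(C)cc2)cc1` is derived from compound 2 by ethoxy in place of sulfamoyl on an aromatic carbon. Going by the values given here, no measured pair shows this change, so the numbers give no direct guide. Every measured compound keeps the sulfamoyl, and compound 4 lacks it; the step of a 2.7-fold higher number from compound 2 to compound 4 (0.43 log units; beyond the scatter) is expected to run toward weaker inhibition. Compound 4 is estimated at 250000 nM, with a range from 60000 nM to 1000000 nM in this assay.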

Compound 4, inhibition constant: 128 nM
Compound 4: the middle estimate sits 2000-fold (3.29 log units) above what was measured; the measured number lies below the stated range.
By their numbers in this assay, from the lowest: compound 3; then compound 4; then compound 1; then compound 2.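

Putting ethoxy in place of sulfamoyl on this aromatic carbon, para to a large group, gives a 720-fold lower number from compound 2 to compound 4 (2.86 log units; beyond the scatter) and so much stronger inhibition. Every earlier compound carried the sulfamoyl, and this pair shows that, at this position, inhibition does not depend on it. No measurement on hand accounts for the gain.

As far as these compounds go, whether the gain comes from ethoxy arriving or from sulfamoyl leaving stays open, and a hydroxyl, an amine or a longer chain at this position could help separate the two. From the compounds shown here alone, whether the same change would help compound 1 or compound 3 also remains unknown.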